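Cyano in place of 2-cyanoethenyl: an expected step

The source may report more compounds than this note shows. Statements on the series, on what has been measured and on what is new or still open speak of the compounds shown alone.

Measured so far in a physicochemical assay for solubility, with a stated time of 4 h, at pH 2.0; a lower number here means a less soluble compound, a higher number a more soluble compound
Compound 1 `CC(=O)CCc1cc(C)c(Oc2cc(Nc3ccc(C#N)cc3)c(N)cc2C(F)(F)F)c(C)c1` gives 0.28 ug/mL
Compound 2 `Cc1cc(CCC#N)cc(C)c1Oc1cc(Nc2ccc(C#N)cc2)c(N)cc1C(F)(F)F` gives 0.33 ug/mL
Compound 3 `Cc1cc(/C=C/C#N)cc(C)c1Oc1cc(Nc2ccc(C#N)cc2)c(N)cc1C(F)(F)F` gives 0.42 ug/mL

Compound 3, at 0.42 ug/mL, stands within the scatter of both compound 1 and compound 2, so no order can be read among the three. The next structure, compound 4 `Cc1cc(C#N)cc(C)c1Oc1cc(Nc2ccc(C#N)cc2)c(N)cc1C(F)(F)F`, carries cyano in place of 2-cyanoethenyl on an aromatic carbon. The closest evidence concerns the same side chain: the measured change is a 1.3-fold higher number from compound 2 to compound 3 (0.10 log units; within the scatter). Two further changes at the chain bear on it, a 1.2-fold higher number from compound 1 to compound 2 (0.07 log units; within the scatter) and a 1.5-fold higher number from compound 1 to compound 3 (0.18 log units; within the scatter). All three stay within the scatter in this assay. None of them shows what happens when the chain is replaced by cyano directly on the aromatic carbon, so the evidence is indirect and the range must stay wide. The expected step is a 1.1-fold lower number from compound 3 to compound 4 (0.02 log units; within the scatter), which means no change beyond the scatter is anticipated, in either direction. For compound 4 the estimated value is 0.4 ug/mL, with an expected range from 0.15 ug/mL to 1 ug/mL.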

Compound 4, solubility: 0.96 ug/mL
For compound 4 the middle estimate is 2.4-fold (0.38 log units) below the measured one, within the range that was stated.
By their numbers in this assay, from the lowest: compounds 1, 2 and 3 (each within the scatter of the next); then compound 4.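

In this assay, going by these compounds alone, cyano set directly on the aromatic carbon brings the first change at this position that lies beyond the scatter: a 2.3-fold higher number from compound 3 to compound 4 (0.36 log units; beyond the scatter), alongside a 2.9-fold higher number from compound 2 to compound 4 (0.46 log units; beyond the scatter) and a 3.4-fold higher number from compound 1 to compound 4 (0.54 log units; beyond the scatter). The 2-acetylethyl, 2-cyanoethyl and 2-cyanoethenyl compounds could not be told apart, so among these four compounds, the chain's end group and its double bond gave no readable difference, whereas replacing the chain with cyano did. Nothing measured among the compounds shown accounts for this step.

The compounds shown leave open whether the higher number goes with the nitrile itself or with the shorter group, a question that an amine or a carboxylic acid on the same aromatic carbon could address. Also open, going by these compounds, is whether cyanomethyl, a chain of intermediate length, would stand with compound 4 or with the three longer-chain compounds.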